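Series notes: biaryl carboxylic acids

The compounds below may be only part of what the source reports. "The series", "measured", "known", "first", "only" and "open" are said of these compounds alone.

Measured compounds:
compound 1 `O=C1c2ccc(OCc3cccc(-c4ccc(Cl)cc4F)c3)cc2CN1C1CCCC1`: "not determined" (no result reported)
compound 2 `COc1ccc(C(=O)O)cc1-c1cccc(COc2ccc3c(c2)CN(C2CCCC2)C3=O)c1`: 100%
compound 3 `O=C(O)c1cc(-c2cccc(COc3ccc4c(c3)CN(C3CCCC3)C4=O)c2)ccc1O`: 98%

In an ADME assay on a cell-free system (plasma, Rattus norvegicus) for metabolic stability, read by LC-MS, with a stated time of 1 h, at 37 degrees C, tested at 100 uM (on this read-out higher numbers stand for a more stable compound and lower numbers for a less stable compound), compound 2 gives 100% and compound 3 gives 98%. Within the data shown here, the only step between measured compounds, a number 2 percentage points lower from compound 2 to compound 3 (within the scatter), shows that exchanging one carboxy-bearing aryl group for another leaves the read-out where it was. Compound 1 has no number in this assay, so there is no measured starting point for the step to compound 4.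

Compound 4 `O=C(O)c1ccc(Cl)c(-c2cccc(COc3ccc4c(c3)CN(C3CCCC3)C4=O)c2)c1` differs from compound 1 in that (5-carboxy-2-chlorophenyl in place of 4-chloro-2-fluorophenyl on an aromatic carbon). Like compound 2 and compound 3, compound 4 carries a carboxy group on the terminal aryl ring, and both of those compounds sit at the top of the scale in this assay. Among the measured compounds shown here, no measured step describes the exchange of 4-chloro-2-fluorophenyl for a carboxy-bearing ring, so the expectation rests on compound 2 and compound 3 alone.

Compound 4 is therefore expected to be essentially fully stable, estimated at 98% with a range of 88% to 100%.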

Compound 4, percent of the compound remaining: 100%
Compound 4: middle estimate off by 2 percentage points, on the low side, and the stated range covers the measured number.
By their numbers in this assay, from the lowest: compounds 3, 2 and 4 (each within the scatter of the next).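

With compound 4, 5-carboxy-2-chlorophenyl joins the carboxy-bearing rings at this position in this assay. Chloro in place of methoxy on an aromatic carbon gives no change at the digits printed from compound 2 to compound 4 (within the scatter) and so adds a halogen-bearing ring to the set, while 5-carboxy-2-chlorophenyl in place of 3-carboxy-4-hydroxyphenyl gives a number 2 percentage points higher from compound 3 to compound 4 (within the scatter) as the second comparison. Across compounds 2, 3 and 4 the read-out therefore stays level whether the carboxy-bearing ring also carries methoxy, hydroxy or chloro. No supporting evidence bears on why the read-out stays level.

Still open, going by these compounds, is whether this level holds with a methyl ester or a primary amide in place of the carboxylic acid. Also open, on these data alone, is whether it holds with the carboxylic acid on a longer chain off the ring.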